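Furan to phenyl swap at the ring nitrogen position

The source may report more compounds than this note shows. Statements on the series, on what has been measured and on what is new or still open speak of the compounds shown alone.

Compound 1 `Oc1ccc(-c2cc(-c3cccc(Cl)c3)nc(-c3ccco3)c2)cc1` gives 5220 nM in a functional assay on T47D cells (Homo sapiens) for cytotoxicity, read by CCK-8 assay and cell counting, with a stated time of 2 days (a lower number here means a stronger inhibitor, a higher number a weaker inhibitor), the lowest of the two numbers measured. Among the measured compounds shown here, compound 2 `Oc1ccc(-c2cc(-c3ccc(Cl)cc3)nc(-c3ccco3)c2)cc1` gives 6260 nM; the only measured step, a 1.2-fold higher number from compound 1 to compound 2 (0.08 log units; within the scatter), concerns a different part of the molecule. Compound 3 `Oc1ccc(-c2cc(-c3ccccc3)nc(-c3cccc(Cl)c3)c2)cc1` differs from compound 1 by phenyl in place of furan-2-yl on an aromatic carbon. For the measured compounds named here, no measured step touches this change, so nothing supports a direction; the expectation for compound 3 is therefore a step not beyond the scatter, a 1.1-fold higher number from compound 1 to compound 3 (0.02 log units; within the scatter), with wide uncertainty. Compound 3 is estimated at 5500 nM, with a range from 1800 nM to 17000 nM.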

Compound 3, half-maximal inhibitory concentration: 4790 nM
Beside the measured number, compound 3's estimate is 1.1-fold (0.06 log units) above it, and the stated range covers the measured number.
By their numbers in this assay, from the lowest: compounds 3, 1 and 2 (each within the scatter of the next).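

Among the compounds shown here, the step of a 1.1-fold lower number from compound 1 to compound 3 (0.04 log units; within the scatter) in this assay is the first reading at the position next to the ring nitrogen, since the earlier pair varied only the chlorophenyl group. With phenyl in place of furan-2-yl, the ring hetero atom and its hydrogen-bond acceptor leave without a step beyond the scatter. Nothing available explains why the two groups read alike.

Still open, going by these compounds, is whether this position accepts anything other than an aromatic ring, such as an amine or a carboxylic acid.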